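A few compounds are considered here, and "the series" means these few. Any claim that something is new, unique, unknown or untested is made for them only; others in the source may bear on it.

Of the compounds shown here, three sharing one core have been measured in an assay for binding affinity to Corticotropin releasing factor receptor (Rattus norvegicus); a higher number here means a weaker inhibitor, a lower number a stronger inhibitor. Compound 1 `CCc1nc2c(-c3ccc(Cl)cc3Cl)ccnc2n1[C@H](CC)C1CC1` gives 0.2 nM. Compound 2 `CCc1nc2c(-c3ccc(Cl)cc3Cl)ccnc2n1[C@H](C)C1CC1` gives 0.6 nM. Compound 3 `CCc1nc2c(-c3ccc(Cl)cc3Cl)ccnc2n1C(C)CC` gives 1.3 nM, the highest of the three numbers.

Compound 3 differs from compound 2 by sec-butyl in place of 1-cyclopropylethyl on an aromatic nitrogen; in this assay that change gave a 2.2-fold higher number from compound 2 to compound 3 (0.34 log units; beyond the scatter). Compound 1 differs from compound 2 by methyl in place of hydrogen on a saturated chain carbon, two bonds along the chain from an aromatic nitrogen and a saturated ring carbon, and that change gave a 3.0-fold lower number from compound 2 to compound 1 (0.48 log units; beyond the scatter).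

Compound 4 `CCc1nc2c(-c3ccc(Cl)cc3Cl)ccnc2n1C(CC)CC` has not yet been measured. It differs from compound 3 by methyl in place of hydrogen on a saturated chain carbon, two bonds along the chain from an aromatic nitrogen. Among the compounds with values here, this is the same kind of change as the one from compound 2 to compound 1, but not the same: in compound 1 the carbon that receives the methyl is two bonds along the chain from an aromatic nitrogen and a saturated ring carbon, whereas in compound 4 it is two bonds along the chain from an aromatic nitrogen only, with no ring on that chain.

Because the earlier step gave a 3.0-fold lower number from compound 2 to compound 1 (0.48 log units; beyond the scatter), compound 4 is expected to give a lower number than compound 3, by a step estimated as a 2.6-fold lower number from compound 3 to compound 4 (0.41 log units; beyond the scatter). Starting from compound 3 at 1.3 nM, compound 4 is estimated at 0.5 nM, most likely between 0.2 nM and 1.3 nM, since only one such step has been seen and its surroundings were not identical.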

Compound 4, inhibition constant: 1 nM
Estimate against measurement, compound 4: 2.0-fold (0.30 log units) below; the range from low to high includes it.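

In this assay, the methyl that turns sec-butyl into pentan-3-yl gave a 1.3-fold lower number from compound 3 to compound 4 (0.11 log units; within the scatter), so on this core the change cannot be told apart from no change at all. Pentan-3-yl in place of 1-cyclopropylethyl gave a 1.7-fold higher number from compound 2 to compound 4 (0.22 log units; within the scatter), which also cannot be told apart from no change, whereas pentan-3-yl in place of 1-cyclopropylpropyl gave a 5.0-fold higher number from compound 1 to compound 4 (0.70 log units; beyond the scatter), a real difference. Set beside each other, the two methyl steps do not differ measurably, even though only one of them stands clear of the scatter on its own: the same change on two cores in this assay, a 3.0-fold lower number (0.48 log units; beyond the scatter) from compound 2 to compound 1 and a 1.3-fold lower number (0.11 log units; within the scatter) from compound 3 to compound 4, 2.3-fold (0.36 log units) apart, within the scatter of two such steps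

This does not show that the methyl carries over from one core to the other at full size, nor that its effect fades on a chain with no cyclopropyl ring, since each core offers a single pair and the gap between them may be scatter alone.

The compounds shown leave open how the same methyl would behave with other groups on the aromatic nitrogen, such as a cyclobutyl ring in place of cyclopropyl or a longer chain in place of the ethyl arms of pentan-3-yl. A further pair of this kind would be needed to tell whether the step depends on the ring at all.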